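The compounds below may be only part of what the source reports. "The series", "measured", "known", "first", "only" and "open" are said of these compounds alone.

Of the compounds shown here, three have been measured in an ADME assay on CEM-SS cells (Homo sapiens) for cytotoxicity, read by XTT assay, with a stated time of 6 days; a lower number here means that less compound is tolerated, a higher number that more compound is tolerated. Compound 2 `CCCC(=O)OCSc1ccccc1C(=O)NCCCNC(C)=O` gives 21.1 uM. Compound 3 `CCCC(=O)OC[Se]c1ccccc1C(=O)NCC(N)=O` gives 6.8 uM. Compound 1 `CCCC(=O)OCSc1ccc(OC(F)(F)F)cc1C(=O)NC(C)(C)C(N)=O` reaches only a limit of the assay, < 56.1 uM, so it is not a number. Among the two numbers, compound 2 stands highest; its nearest neighbour, compound 3, sits at a lower number, a gap beyond the scatter.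

Compound 4 `CCCC(=O)OCSc1ccccc1C(=O)NC` has not yet been measured in this assay. It differs from compound 2 in one place: hydrogen in place of 2-acetamidoethyl on a saturated chain carbon bound to an amide-type nitrogen. Going by the values given here, no step between measured compounds is available here, so the expectation rests on compound 2 alone. The step is expected to stay within the usual scatter, with no clear direction: a 1.2-fold higher number from compound 2 to compound 4 (0.07 log units; within the scatter). Compound 4 is therefore estimated at 25 uM, within a range from 10 uM to 60 uM.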

Compound 4, half-maximal toxic concentration: 5.7 uM
Estimate against measurement, compound 4: 4.4-fold (0.64 log units) above, and the stated range ends above it.
By their numbers in this assay, from the lowest: compounds 4 and 3 (each within the scatter of the next); then compound 2.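

Replacing 2-acetamidoethyl with hydrogen, on a saturated chain carbon bound to an amide-type nitrogen, gives a 3.7-fold lower number from compound 2 to compound 4 (0.57 log units; beyond the scatter) in this assay. This single pair shows that what sits at this place can change how much compound the cells tolerate, with less tolerated once the 2-acetamidoethyl group is gone. Nothing measured here accounts for the change.

From the compounds shown here alone, whether the number depends on chain length alone or on the acetamide end stays open. A plain propyl chain, or a chain ending in an amine or a carboxylic acid, would help separate these two readings.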